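The source may report more compounds than this note shows. Statements on the series, on what has been measured and on what is new or still open speak of the compounds shown alone.

Compound 1 `Fc1ccc(Cc2ccc3c(NCCCNCc4ccco4)ccnc3c2)cc1`: 9.47
Compound 2 `COc1cccc(CNCCCNc2ccnc3cc(Cc4ccc(F)cc4)ccc23)c1O`: 9.47
Compound 3 `COc1ccc(F)cc1CNCCCNc1ccnc2cc(Cc3ccc(F)cc3)ccc12`: 9.47

In a physicochemical assay for acid dissociation, compound 2 gives 9.47, level with compound 1 and compound 3. The measured steps all change the aryl group on the saturated chain carbon bound to the amine nitrogen, and each left the number where it was: no change at the digits printed from compound 1 to compound 2 (within the scatter), no change at the digits printed from compound 1 to compound 3 (within the scatter), no change at the digits printed from compound 2 to compound 3 (within the scatter). Compound 4 `COc1cccc(CNCCCNc2ccnc3cc(-c4ccccc4)ccc23)c1O` differs from compound 2 elsewhere: phenyl in place of 4-fluorobenzyl on an aromatic carbon. Among the measured compounds shown here, no measured step touches this aromatic carbon of the fused core, so none bears directly on it; the only guide is that varying a distant group has not moved the reading at all. Expected, then, is a step of no change at the digits printed from compound 2 to compound 4 (within the scatter), nothing beyond the scatter. Compound 4 is estimated at 9.47, between 9 and 9.9.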

Compound 4, acid dissociation constant: 9.47
The estimate for compound 4 equals the measured number at the digits printed, within the range that was stated.
By their numbers in this assay, from the lowest: compounds 1, 2, 3 and 4 (each within the scatter of the next).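

The earlier steps shown here changed only the aryl group on the chain, whereas this one changes an aromatic carbon of the shared core. In this assay, putting phenyl in place of 4-fluorobenzyl there gives no change at the digits printed from compound 2 to compound 4 (within the scatter). A smaller group without fluorine thus leaves the reading level at this position, at least for this one pair. Nothing measured here offers an explanation for this result. As far as these compounds go, whether an amine or a carboxylic acid on this aromatic carbon would also leave the reading level remains open, as does the outcome of a longer chain in the linker.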